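Swapping the Pyridinylmethyl Amine of Compound 1

The source may report more compounds than this note shows. Statements on the series, on what has been measured and on what is new or still open speak of the compounds shown alone.

Of the compounds shown here, three sharing one core have been tested in an assay on HEK293 cells for inhibition of Steryl-sulfatase (Homo sapiens), tested at 0.1 uM; on this read-out higher numbers stand for a stronger effect at the one concentration tested and lower numbers for a weaker effect. Compound 1 `CCN(Cc1cccnc1)c1ccc(C(=O)N2CCc3ccc(OS(N)(=O)=O)cc3C2)cc1` gives 35.7%, the highest of the three numbers. Compound 3 `NS(=O)(=O)Oc1ccc2c(c1)CN(C(=O)c1cccc(N3CCc4ccccc4C3)c1)CC2` gives 24.1%, and compound 2 `NS(=O)(=O)Oc1ccc2c(c1)CN(C(=O)c1cccc(N3CCCCC3)c1)CC2` gives 1%, the lowest. For the measured compounds named here, the one step between measured neighbours, a number 23.1 percentage points higher from compound 2 to compound 3 (beyond the scatter), is the only guide so far; it concerns the amine on the other aromatic ring and says nothing direct about the group changed here.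

Compound 4 `CN(CCCN1CCCCC1)c1ccc(C(=O)N2CCc3ccc(OS(N)(=O)=O)cc3C2)cc1` differs from compound 1 in one place: methyl(3-(piperidin-1-yl)propyl)amino in place of ethyl((pyridin-3-yl)methyl)amino on an aromatic carbon. Going by the values given here, no measured pair changes this group, so the direction of the step is open. Among the compounds with values here, the only hint is that compound 2, which carries a piperidin-1-yl, gives 1%, while compound 3 with a bicyclic aromatic amine gives 24.1%, but that change sits at a different place and may not carry over.

With this thin support, the step from compound 1 to compound 4 is expected to be a modest loss, a number 15.7 percentage points lower from compound 1 to compound 4 (beyond the scatter), and compound 4 is estimated to give 20% in this assay, within a wide range from 0% to 45%.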

Compound 4, a percentage reported as inhibition, at one concentration (the size of the read-out at that concentration, not a potency): 17.4%
Beside the measured number, compound 4's estimate is 2.6 percentage points above it; low and high end bracket the measured number.
By their numbers in this assay, from the lowest: compound 2; then compounds 4 and 3 (each within the scatter of the next); then compound 1.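

In this assay, the group on the aromatic carbon para to a large group now has its first measured change, and it gives a number 18.3 percentage points lower from compound 1 to compound 4 (beyond the scatter). The position is therefore not indifferent to what it carries: methyl(3-(piperidin-1-yl)propyl)amino, with its six-membered non-aromatic ring, does worse here than ethyl((pyridin-3-yl)methyl)amino, with its six-membered aromatic ring, even though both groups count the same hydrogen-bond donors and acceptors and neither has a net charge. Nothing available explains this loss.

This single swap alters the ring, the chain and the small alkyl group on the nitrogen together, so the compounds shown cannot say which of these changes accounts for the lower number. A methyl in place of the ethyl with the pyridin-3-ylmethyl kept, a morpholine in place of the piperidine at the end of the propyl chain, or a plain dimethylamino group would each help to separate these parts.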